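This account rests on a few compounds, and the source may have more. Where it says the series, first, only, none or still open, it means among the compounds named here.

Measured compounds:
Compound 1, `CN1CCCC(NC(=O)c2ccc(C(F)(F)F)cc2C(F)(F)F)(c2ccccc2)C1`: in an assay on cells for inhibition of sodium- and chloride-dependent glycine transporter 1 (Homo sapiens) (a higher number here means that more compound is needed for the effect, a lower number that less compound is needed), compound 1 gives 540 nM.
Compound 2, `CN1CCCC(NC(=O)c2ccc(C(F)(F)F)cc2)(c2ccccc2)C1`: in this assay compound 2 gives > 10000 nM, which is a limit of the assay and not a number.

Compound 2 stands at the limit of > 10000 nM in this assay, at which 1 of the 2 values shown sits, so its position among the measured values is known only as a limit. Within the data shown here, the single measured step is the removal of the second trifluoromethyl from compound 1, giving an at least 18-fold higher number from compound 1 to compound 2 (1.26 log units; beyond the scatter); the true size of that loss is open, since compound 2 is a limit.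

Compound 3 is `CN1CCCC(NC(=O)c2ccc(C(F)(F)F)cc2C#N)(c2ccccc2)C1`, to be measured in this assay. Relative to compound 2 the change is cyano in place of hydrogen on an aromatic carbon. This re-occupies the aromatic carbon left bare in the step from compound 1, and that step bears on it directly: restoring a substituent at this carbon is expected to lower the number in this assay, while the cyano is a different group from the trifluoromethyl it replaces, so a full return to the value of compound 1 is not assumed.

Compound 3 is therefore expected to give about 2500 nM in this assay, within 600 nM to 10000 nM. The expected step is an at least 4.0-fold lower number from compound 2 to compound 3 (0.60 log units; beyond the scatter).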

Compound 3, half-maximal effective concentration: > 10000 nM
Compound 3: a limit, no number (the forecaster's own chance of this, stated with the estimate: 25%); middle value at least 4.0-fold (0.60 log units) from the limit.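

In this assay compound 3 gives > 10000 nM, which is a limit of the assay and not a number. Placing cyano instead of trifluoromethyl on this aromatic carbon, ortho to a large group and meta to a trifluoromethyl group, gives an at least 18-fold higher number from compound 1 to compound 3 (1.26 log units; beyond the scatter), so among the compounds shown, occupying this carbon is not enough on its own to keep a measurable value, and only trifluoromethyl there gives one. The step between compound 2 and compound 3 cannot be read, since both values are limits, and the gain expected from cyano over hydrogen therefore finds no support in these data: the limit of > 10000 nM in this assay, at which 2 of the 3 values shown sit.

As far as these compounds go, how far compound 2 and compound 3 lie beyond the limit remains unknown, so hydrogen and cyano cannot be ordered at this carbon. Also open, from the compounds shown here alone, is whether the value of compound 1 depends on trifluoromethyl specifically, or whether another group on this carbon, such as chlorine, methyl or methoxy, would also bring a number within the reach of this assay.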